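The compounds below may be only part of what the source reports. "The series", "measured", "known", "first", "only" and "open" are said of these compounds alone.

Measured compounds:
- compound 1, `Cc1c(C(=O)Nc2ccc(Oc3ccnc4[nH]ccc34)c(F)c2)nnn1-c1ccccc1`: 350 nM
- compound 2, `Cc1c(C(=O)Nc2ccc(Oc3ccnc4[nH]ccc34)cc2)nnn1-c1ccccc1F`: 280 nM
- compound 3, `O=C(Nc1ccc(Oc2ccnc3[nH]ccc23)c(F)c1)c1nnn(-c2ccccc2)c1C(F)(F)F`: 1150 nM

All three were tested in a functional assay on MCF7 cells (Homo sapiens) for cytotoxicity, read by MTT assay, with a stated time of 72 h; a higher number here means a weaker inhibitor, a lower number a stronger inhibitor. Compound 1 gives 350 nM. Compound 2 gives 280 nM. Compound 3 gives 1150 nM. Compound 3 arises from compound 1 by one change, (trifluoromethyl in place of methyl on an aromatic carbon), and that step is a 3.3-fold higher number from compound 1 to compound 3 (0.52 log units; beyond the scatter). Compound 2 and compound 1 share the same atoms joined differently; the difference between the two cores is not broken down here.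

Compound 4, `O=C(Nc1ccc(Oc2ccnc3[nH]ccc23)cc1)c1nnn(-c2ccccc2F)c1C(F)(F)F`, is not yet measured in this assay. It arises from compound 2 by the same kind of change, (trifluoromethyl in place of methyl on an aromatic carbon); the place differs only in that it is next to the ring atom that bears a 2-fluorophenyl group rather than a phenyl group. Because the earlier step was a 3.3-fold higher number from compound 1 to compound 3 (0.52 log units; beyond the scatter), a step of about a 3.2-fold higher number from compound 2 to compound 4 (0.51 log units; beyond the scatter) is expected here. Compound 4 is therefore estimated at 900 nM, likely between 450 nM and 1800 nM.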

Compound 4, half-maximal inhibitory concentration: 290 nM
Estimate against measurement, compound 4: 3.1-fold (0.49 log units) above; measured number outside the range, below it.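

In this assay, the swap of methyl for trifluoromethyl does not carry the same size of step from one core to the other: the same change on two cores in this assay, a 3.3-fold higher number (0.52 log units; beyond the scatter) from compound 1 to compound 3 and a 1.0-fold higher number (0.02 log units; within the scatter) from compound 2 to compound 4, 3.2-fold (0.50 log units) apart, beyond the scatter of two such steps

On the newer core, the step is a 1.0-fold higher number from compound 2 to compound 4 (0.02 log units; within the scatter), so the loss seen on the core of compound 1 cannot be assumed to transfer to other cores in this series. This single pair of steps does not show which difference between the two cores matters, since they share the same atoms joined differently, nor does it give a rule for other cores.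

The compounds shown leave open how an ethyl group, a longer chain or an amine in the same place would behave on either core.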